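A Sulfonyl for a Benzyl on the Quinolone Nitrogen

The source may hold more compounds than are shown below. What is called first, only, known or untested is meant among the compounds shown, and "the series" means these compounds.

The study concerns three measured compounds sharing one core and a fourth awaiting measurement. Compound 1 `COc1ccc(-c2cc(=O)c3c(OC)cc(OC)cc3n2Cc2ccccc2)cc1` was tested in a functional assay on KOPN-8 cells (Homo sapiens) for antiproliferative activity, with a stated time of 72 h; on this read-out higher numbers stand for an effect only at larger amounts of compound and lower numbers for an effect already at smaller amounts. In this assay compound 1 gives > 17300 nM, which is a limit of the assay rather than a number. Compound 1 therefore stands at the limit of > 17300 nM in this assay, at which 1 of the 3 values shown sits, so its position among the values shown cannot be fixed more closely. Compound 2 `COc1ccc(-c2c(Cl)c(=O)c3c(OC)cc(OC)cc3n2S(=O)(=O)c2ccc(OC)cc2)cc1` gives 19100 nM in this assay. Compound 3 `COC(=O)c1cc(=O)c2c(OC)cc(OC)cc2n1C` gives > 19000 nM in this assay, which is likewise a limit. Compound 4 `COc1ccc(-c2cc(=O)c3c(OC)cc(OC)cc3n2S(=O)(=O)c2ccc(C#N)cc2)cc1` has not yet been measured. It differs from compound 1 by (4-cyanophenyl)sulfonyl in place of benzyl on an aromatic nitrogen. Going by the values given here, no step between measured compounds is available, so the size of this change can only be expected. Since compound 2 carries a sulfonyl on the same nitrogen and gives 19100 nM, the step that the limit leaves unreadable from compound 1 to compound 4 is expected to be none beyond the scatter. Compound 4 is thus estimated at 18000 nM, between 7000 nM and 40000 nM.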

Compound 4, half-maximal effective concentration: > 17200 nM
Compound 4: a limit, no number (the forecaster's own chance of this, stated with the estimate: 55%); the middle value is on the limit's open side.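

In this assay compound 4 gives > 17200 nM, which is a limit. Going by these compounds alone, with compound 1 also at a limit, no step from compound 1 to compound 4 can be read. The compounds shown leave open whether (4-cyanophenyl)sulfonyl in place of benzyl on the aromatic nitrogen changes the effect at all.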